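The source may hold more compounds than are shown below. What is called first, only, known or untested is meant among the compounds shown, and "the series" means these compounds.

Compound 2 `O=c1[nH]/c(=N\OCCCc2cccc(I)c2)ccn1[C@@H]1O[C@H](COP(=O)(O)OP(=O)(O)OP(=O)(O)O)[C@@H](O)[C@H]1O` gives the lowest of the two numbers obtained in a functional assay on 1321-N1 cells for agonist activity at P2Y purinoceptor 4 (Homo sapiens), read by scintillation counting and inositol phosphate accumulation (on this read-out lower numbers stand for an effect already at smaller amounts and higher numbers for an effect only at larger amounts of compound), namely 114 nM, while compound 1 `O=C(O)CCCO/N=c1/ccn([C@@H]2O[C@H](COP(=O)(O)OP(=O)(O)OP(=O)(O)O)[C@@H](O)[C@H]2O)c(=O)[nH]1` gives 470 nM. Among the measured compounds shown here, the only measured step is a 4.1-fold lower number from compound 1 to compound 2 (0.62 log units; beyond the scatter). Compound 3 `O=c1[nH]/c(=N\OCCCc2cccnc2)ccn1[C@@H]1O[C@H](COP(=O)(O)OP(=O)(O)OP(=O)(O)O)[C@@H](O)[C@H]1O` differs from compound 2 by pyridin-3-yl in place of 3-iodophenyl on a saturated chain carbon, three bonds along the chain from an oxygen. For the measured compounds named here, no measured step covers an exchange of one aromatic ring for another at this place on the chain. Going by the values given here, the single step available shows only that the group there can shift the number modestly. A shift of similar size, or none beyond the scatter, is therefore expected, and compound 3 is estimated at 250 nM (range 90 nM to 700 nM), a step of a 2.2-fold higher number from compound 2 to compound 3 (0.34 log units; beyond the scatter).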

Compound 3, half-maximal effective concentration: 300 nM
Compound 3: middle estimate off by 1.2-fold (0.08 log units), on the low side, within the range that was stated.
By their numbers in this assay, from the lowest: compound 2; then compounds 3 and 1 (each within the scatter of the next).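

In this assay, the exchange of one aromatic ring for another at this place on the chain moves the number: pyridin-3-yl in place of 3-iodophenyl gives a 2.6-fold higher number from compound 2 to compound 3 (0.42 log units; beyond the scatter) and so stands beyond the scatter. Pyridin-3-yl in place of carboxy gives only a 1.6-fold lower number from compound 1 to compound 3 (0.19 log units; within the scatter), so an aromatic ring here does not by itself set a compound apart from compound 1. No evidence bears on what lies behind these steps.

On these data alone, whether a plain phenyl, a 3-chlorophenyl or an amine on this chain would fall nearer compound 2 or compound 3 stays open, as does the effect of a longer chain.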